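Diacylhydrazine series: aryl to pentyl on the acyl carbon

This account rests on a few compounds, and the source may have more. Where it says the series, first, only, none or still open, it means among the compounds named here.

Measured so far:
compound 1 `CC(C)(C)N(NC(=O)c1ccccc1I)C(=O)c1ccccc1Cl` — 1290 nM
compound 2 `Cc1ccc(C(=O)NN(C(=O)c2ccccc2Cl)C(C)(C)C)cc1` — 18.6 nM
compound 3 `Cc1ccc(C(=O)NN(C(=O)c2cc(C)cc(C)c2)C(C)(C)C)cc1` — 12 nM

In an assay on cells for agonist activity at ecdysone receptor (Bombyx mori), read by a luciferase reporter, with a stated time of 24 h (a higher number here means that more compound is needed for the effect, a lower number that less compound is needed), compound 3 gives the lowest number of the three; compound 2 sits within the scatter of it, so no order between the two can be read, while compound 1 stands well apart, a 69-fold lower number from compound 1 to compound 2 (1.84 log units; beyond the scatter) and then a 1.6-fold lower number from compound 2 to compound 3 (0.19 log units; within the scatter). Compound 4 `CCCCCC(=O)NN(C(=O)c1cc(C)cc(C)c1)C(C)(C)C` differs from compound 3 in one place: pentyl in place of 4-methylphenyl on a carbonyl carbon. Neither measured step bears directly on this change. The step from compound 1 to compound 2 swaps one aryl group for another and is large; the step from compound 2 to compound 3 swaps aryl for aryl on the other carbonyl and is within the scatter. Within the data shown here, no step here removes an aromatic ring altogether, so the size of the change is unguided; a worsening of some size is expected, since both small-number compounds carry two aryl groups. Compound 4 is therefore expected to give 500 nM in this assay, range 60 nM to 5000 nM, an estimated step of a 42-fold higher number from compound 3 to compound 4 (1.62 log units; beyond the scatter).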

Compound 4, half-maximal effective concentration: 79.4 nM
Estimate against measurement, compound 4: 6.3-fold (0.80 log units) above, and the stated range covers the measured number.
By their numbers in this assay, from the lowest: compounds 3 and 2 (each within the scatter of the next); then compound 4; then compound 1.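

Swapping the 4-methylphenyl on this carbonyl carbon for pentyl gives a 6.6-fold higher number from compound 3 to compound 4 (0.82 log units; beyond the scatter), a step beyond the scatter but much smaller than a 69-fold lower number from compound 1 to compound 2 (1.84 log units; beyond the scatter). With the 3,5-dimethylphenyl on the other carbonyl held fixed, an aromatic ring at this place is therefore not a requirement for a response: compound 4, with an open chain, gives 79.4 nM. No evidence at hand bears on why this change has the size it does.

With pentyl as the only chain shown, the effect of a shorter butyl chain, a longer heptyl chain, a branched chain or a saturated cyclohexyl ring on this carbonyl carbon remains open. Also open, going by these compounds, is whether pentyl would give a step of similar size with 2-chlorophenyl on the other carbonyl.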